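The source may hold more compounds than are shown below. What is called first, only, known or untested is meant among the compounds shown, and "the series" means these compounds.

Compound 1, `COC(=O)c1sc2ccccc2c1C#Cc1ccc(OC)cc1`: 103000 nM
Compound 2, `COC(=O)c1sc2cc(OC)ccc2c1C#Cc1ccccc1`: 42300 nM

In a functional assay on cells (CNS cell, Homo sapiens) for cytotoxicity, read by sulforhodamine B assay, with a stated time of 48 h (a lower number here means a stronger inhibitor of growth, a higher number a weaker inhibitor of growth), compound 2 holds the lower of the two numbers; compound 1 gives 103000 nM, a gap beyond the usual scatter. Compound 3, `COC(=O)c1sc2cc(OC)ccc2c1C#Cc1ccc(F)cc1`, differs from compound 2 only by fluoro in place of hydrogen on an aromatic carbon. Among the measured compounds shown here, no measured pair shows this change, so the expected step from compound 2 to compound 3 is small and not beyond the scatter, leaning if anything toward a lower number: a 1.2-fold lower number from compound 2 to compound 3 (0.08 log units; within the scatter). On that basis compound 3 is expected to give 35000 nM, within a range of 15000 nM to 90000 nM.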

Compound 3, concentration for 50% growth inhibition: 10100 nM
For compound 3 the middle estimate is 3.5-fold (0.54 log units) above the measured one; measured number outside the range, below it.
By their numbers in this assay, from the lowest: compound 3; then compound 2; then compound 1.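

In this assay, the change from phenyl to 4-fluorophenyl gives a 4.2-fold lower number from compound 2 to compound 3 (0.62 log units; beyond the scatter). This shows that the place para to a large group on this ring is sensitive to substitution, as one added fluoro atom moves the number beyond the scatter. Nothing available here accounts for that step. Going by these compounds, whether chloro or an amine in the same place would move the number in the same direction remains open. So does whether the fluoro step would hold on a core without its methoxy group.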